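This account rests on a few compounds, and the source may have more. Where it says the series, first, only, none or still open, it means among the compounds named here.

Two members of the series have been measured in a functional assay on HeLa cells (Homo sapiens); a lower number here means a stronger inhibitor, a higher number a weaker inhibitor. Compound 1 `O=C(O)CSC(CC(=O)c1ccccc1)C(=O)O` gives 15000 nM in this assay, the higher of the two values; compound 2 `Cc1ccc(C)c(C(=O)CC(SCC(=O)O)C(=O)O)c1` gives 2680 nM in this assay, a lower number, and the gap between the two is beyond the usual scatter. Compound 1 therefore stands at the weak end of what has been measured so far.

Compound 3 `O=C(O)CSC(CC(=O)c1ccc(F)cc1)C(=O)O` has not yet been measured. It differs from compound 1 by fluoro in place of hydrogen on an aromatic carbon. Among the measured compounds shown here, no measured pair shows this particular change, so its effect in this assay is unknown. The alteration is small, and the expectation is that the step of a 1.5-fold lower number from compound 1 to compound 3 (0.18 log units; within the scatter) will be modest, toward a somewhat lower number, possibly not beyond the scatter. In this assay compound 3 is expected to give 10000 nM, within a range from 4000 nM to 30000 nM.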

Compound 3, half-maximal inhibitory concentration: 20700 nM
The estimate for compound 3 lay 2.1-fold (0.32 log units) below the measured number; the range from low to high includes it.
By their numbers in this assay, from the lowest: compound 2; then compounds 1 and 3 (each within the scatter of the next).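

In this assay, fluoro in place of hydrogen on an aromatic carbon, para to a large group, gives a 1.4-fold higher number from compound 1 to compound 3 (0.14 log units; within the scatter) and so leaves compound 3 indistinguishable from compound 1. Among the compounds shown here, this is the first step that changes a single place, and it shows that a single fluorine atom at this position of the core of compound 1 does not move the number beyond the scatter. Nothing available bears on the mechanism behind this result.

As far as these compounds go, it remains open whether a larger group at the same position, such as trifluoromethyl, methoxy or an amine, would produce a step beyond the scatter. From the compounds shown here alone, it is also open whether fluoro would give a similarly small step on the dimethyl-substituted ring of compound 2.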